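The source may hold more compounds than are shown below. What is called first, only, known or untested is meant among the compounds shown, and "the series" means these compounds.

The measured compounds and their values:

Compound 1, `Cc1cccc(-n2nncc2CN2C(=O)C3(C(C#N)=C(N)Oc4c(N)cc5nc6ccccc6nc5c43)c3ccccc32)c1`: in a functional assay on HepG2 cells (Homo sapiens) for antiproliferative activity, read by MTT assay, with a stated time of 48 h (on this read-out lower numbers stand for stronger inhibition and higher numbers for weaker inhibition), compound 1 gives > 50000 nM, which is a limit of the assay and not a number.
Compound 2, `N#CC1=C(N)Oc2c(N)cc3nc4ccccc4nc3c2C12C(=O)N(Cc1cnnn1-c1ccc([N+](=O)[O-])cc1)c1ccccc12`: in this assay compound 2 gives > 50000 nM, again only a limit.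
Compound 3, `CCc1cccc(C)c1-n1nncc1CN1C(=O)C2(C(C#N)=C(N)Oc3c(N)cc4nc5ccccc5nc4c32)c2ccccc21`: in this assay compound 3 gives > 50000 nM, also a limit.

Compound 3 therefore stands nowhere in particular among the numbers shown: all three measured compounds sit at the same limit, as the limit of > 50000 nM in this assay, at which 3 of the 3 values shown sit, records, and none can be called stronger or weaker than another. The three steps between them, a step that the two limits leave unreadable from compound 1 to compound 2, a step that the two limits leave unreadable from compound 1 to compound 3 and a step that the two limits leave unreadable from compound 2 to compound 3, are all unreadable for the same reason, so the change of the aryl group on the triazole nitrogen has so far left no readable trace in this assay.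

Compound 4, `Cc1cc(C)cc(-n2nncc2CN2C(=O)C3(C(C#N)=C(N)Oc4c(N)cc5nc6ccccc6nc5c43)c3ccccc32)c1`, continues this series with 3,5-dimethylphenyl in place of 2-ethyl-6-methylphenyl on an aromatic nitrogen. Every measured step that bears on this position is unreadable, and because the limit of > 50000 nM in this assay, at which 3 of the 3 values shown sit, places all three comparators at the limit, no direction for a number no higher from compound 3 to compound 4 (the limit leaves the size open) can be expected beyond the scatter. Compound 4 is therefore estimated at 50000 nM, with a range from 20000 nM to 100000 nM, and most probably it too will return only a limit.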

Compound 4, half-maximal inhibitory concentration: > 50000 nM
Compound 4: a limit, no number; the forecaster's own chance of this, stated with the estimate: 85%; the middle value lies on the limit itself.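

In this assay compound 4 gives > 50000 nM, which is a limit and not a number. Its steps to compound 1, compound 2 and compound 3 therefore cannot be read: the limit of > 50000 nM in this assay, at which 4 of the 4 values shown sit. The compounds shown leave open how these four aryl groups on the aromatic nitrogen rank against one another, since none yields a number.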